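Swapping the aryl group on a sulfonamide nitrogen

This account rests on a few compounds, and the source may have more. Where it says the series, first, only, none or still open, it means among the compounds named here.

Compound 1, with the structure `COc1ccc(NS(=O)(=O)c2ccc(N3CCNC3=O)cc2)cc1`, is the weakest of the three measured compounds in a functional assay on HT-29 cells (Homo sapiens) for antiproliferative activity, read by sulforhodamine B assay, with a stated time of 48 h (a higher number here means a weaker inhibitor, a lower number a stronger inhibitor), where compound 1 gives 800 nM. Its nearest neighbour, compound 2 `O=C1NCCN1c1ccc(S(=O)(=O)Nc2ccc(F)c(F)c2)cc1`, gives 350 nM, and the furthest, compound 3 `O=C1NCCN1c1ccc(S(=O)(=O)Nc2cccc(Oc3ccccc3)c2)cc1`, gives 200 nM. Both are stronger inhibitors than compound 1.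

Compound 4, with the structure `Cc1cccc(NS(=O)(=O)c2ccc(N3CCNC3=O)cc2)c1C`, differs from compound 1 in a single place: 2,3-dimethylphenyl in place of 4-methoxyphenyl on a sulfonamide nitrogen. Going by the values given here, the one measured step that touches the same place is the exchange giving compound 2, which produced a 2.3-fold lower number from compound 1 to compound 2 (0.36 log units; beyond the scatter). Among the compounds with values here, no step is recorded for compound 3, but its value and that of compound 1 point the same way: replacing the 4-methoxyphenyl has so far made the inhibitor stronger. Because the measured step of a 2.3-fold lower number from compound 1 to compound 2 (0.36 log units; beyond the scatter) was modest, a modest improvement is expected here too, so the step from compound 1 to compound 4 is estimated at a 1.8-fold lower number from compound 1 to compound 4 (0.25 log units; within the scatter). Compound 4 is therefore expected to give about 450 nM in this assay, within a range of 200 nM to 1200 nM.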

Compound 4, half-maximal inhibitory concentration: 190 nM
Compound 4: the middle estimate sits 2.4-fold (0.37 log units) above what was measured; the measured number lies below the stated range.
By their numbers in this assay, from the lowest: compounds 4, 3 and 2 (each within the scatter of the next); then compound 1.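

In this assay, the sulfonamide nitrogen accepts an aryl group built of carbon only: 2,3-dimethylphenyl gives a 4.2-fold lower number from compound 1 to compound 4 (0.62 log units; beyond the scatter). The 4-methoxyphenyl it replaces has one hydrogen-bond acceptor and the new group has none, so an acceptor on this ring is not required for activity in these compounds. Exchanging 3,4-difluorophenyl for the same group gives a 1.8-fold lower number from compound 2 to compound 4 (0.27 log units; within the scatter), so these two differently substituted rings cannot be told apart here, and nothing available explains why either change acts as it does.

Still open, from the compounds shown here alone, is whether an unsubstituted phenyl, or a phenyl carrying a single methyl, would hold this activity. It is also unknown how an amine or a carboxylic acid on this ring would fare.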